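Enlarging the Ring on Compound 3

The source may hold more compounds than are shown below. What is called first, only, known or untested is meant among the compounds shown, and "the series" means these compounds.

In a functional assay on MCF7 cells (Homo sapiens) for inhibition, read by CCK-8 assay, with a stated time of 48 h (a higher number here means a weaker inhibitor of growth, a lower number a stronger inhibitor of growth), compound 1 (`Cc1ccc(Nc2ncc(Cl)c(Nc3ccccc3C)n2)cc1`) reaches only a limit, > 100000 nM. Among the measured compounds shown here, compound 2 (`Cc1ccccc1Nc1nc(Nc2ccc(N3CCN(C)CC3)cc2)ncc1Cl`) gives 20600 nM, while compound 3 (`CCN1CCN(c2ccc(Nc3ncc(Cl)c(Nc4ccccc4C)n3)cc2)CC1`) gives 3160 nM, the lowest number so far.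

Compound 4 (`Cc1ccccc1Nc1nc(Nc2ccc(N3CCCN(C)CC3)cc2)ncc1Cl`) places 4-methyl-1,4-diazepan-1-yl in place of 4-ethylpiperazin-1-yl on an aromatic carbon. Two large-group steps set the background: an at least 4.8-fold lower number from compound 1 to compound 2 (0.68 log units; beyond the scatter), at least modest, and an at least 31-fold lower number from compound 1 to compound 3 (1.50 log units; beyond the scatter), large. The closest guide is a 6.5-fold lower number from compound 2 to compound 3 (0.81 log units; beyond the scatter), a modest step between the 4-methyl and 4-ethyl piperazines. Compound 4 returns to a 4-methyl group, so a modest rise is expected, though the larger ring adds uncertainty. The estimated change is a 2.2-fold higher number from compound 3 to compound 4 (0.35 log units; beyond the scatter). Compound 4 is expected at about 7000 nM, with an estimated range of 2000 nM to 25000 nM.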

Compound 4, concentration for 50% growth inhibition: 4290 nM
The estimate for compound 4 lay 1.6-fold (0.21 log units) above the measured number; low and high end bracket the measured number.
By their numbers in this assay, from the lowest: compounds 3 and 4 (each within the scatter of the next); then compound 2. At a limit, above all of these: compound 1.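

With the same atoms joined differently, 4-methyl-1,4-diazepan-1-yl and 4-ethylpiperazin-1-yl cannot be told apart at this place: a 1.4-fold higher number from compound 3 to compound 4 (0.13 log units; within the scatter). Both rings carry a methyl group in the next comparison, yet the seven-membered ring still separates from 4-methylpiperazin-1-yl, with a 4.8-fold lower number from compound 2 to compound 4 (0.68 log units; beyond the scatter), so the methyl group alone does not set the number. The comparison with the plain methyl compound starts from a limit and not a measured number: an at least 23-fold lower number from compound 1 to compound 4 (1.36 log units; beyond the scatter). As far as these compounds go, whether a 4-ethyl-1,4-diazepan-1-yl group or a free secondary amine in the seven-membered ring would shift the number stays open.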